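A few compounds are considered here, and "the series" means these few. Any claim that something is new, unique, unknown or untested is made for them only; others in the source may bear on it.

In a functional assay on WM164 cells (Homo sapiens) for antiproliferative activity, read by sulforhodamine B assay, with a stated time of 48 h (a higher number here means a weaker inhibitor, a lower number a stronger inhibitor), compound 1 `CCCCCCCCCCCCCCNC(=O)[C@@H]1CSC(c2ccc(NC(C)=O)cc2)N1` gives 600 nM and compound 2 `CCCCCCCCCCCCCCCCNC(=O)[C@@H]1CSC(c2ccc(NC(C)=O)cc2)N1` gives 600 nM, so these two are level and together hold the lowest of the three numbers. Compound 3 `CCCCCCCCCCCCCCCCCCNC(=O)[C@@H]1CSC(c2ccc(NC(C)=O)cc2)N1` gives 11600 nM. The measured steps are no change at the digits printed from compound 1 to compound 2 (within the scatter), a 19-fold higher number from compound 2 to compound 3 (1.29 log units; beyond the scatter) and a 19-fold higher number from compound 1 to compound 3 (1.29 log units; beyond the scatter). Compound 4 `CCCCCCCCCCCCCCCCNC(=O)[C@H]1CSC(c2ccc(NC(C)=O)cc2)N1` departs from compound 2 only in its stereochemistry: the two compounds have the same atoms and bonds; at least one stereo element is drawn with a configuration in one of them and without one in the other: 1 of 2 stereo elements differ; a stereocentre at a saturated ring carbon is drawn R in compound 2 and S in compound 4. All three measured steps alter the chain alone, so none of them bears directly on this stereocentre, and the data give no direction for the change. No shift beyond the scatter is therefore firmly expected in this assay. The expected change is a 1.2-fold higher number from compound 2 to compound 4 (0.07 log units; within the scatter). Compound 4 is estimated at 700 nM, within an expected range of 250 nM to 2000 nM.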

Compound 4, half-maximal inhibitory concentration: 1400 nM
For compound 4 the middle estimate is 2.0-fold (0.30 log units) below the measured one; the measured number falls inside the stated range.
By their numbers in this assay, from the lowest: compounds 1 and 2 (each within the scatter of the next); then compound 4; then compound 3.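

In this assay, turning the saturated ring carbon from R to S gives a 2.3-fold higher number from compound 2 to compound 4 (0.37 log units; beyond the scatter), a modest step but one beyond the scatter. Among these compounds, this shows that the configuration at this position registers in the assay, which the earlier steps, all confined to the chain, could not show. From the compounds shown here alone, the reading of this pair rests on one structural fact: the fact that one of compounds 2 and 4 is drawn with a defined configuration and the other without, at the place where they differ Still open is whether the same shift appears with the other chains, and whether a carboxylic acid in place of the chain-bearing amide would respond to this stereocentre.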